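The source may hold more compounds than are shown below. What is called first, only, known or untested is meant among the compounds shown, and "the series" means these compounds.

Measured so far:
Compound 1, `C[C@@H]1CCCN1c1cc2c(N)ncnc2n1C`: 6390 nM
Compound 2, `Cc1n[nH]cc1Nc1nc(N)c2c(C#N)c(N3CCC[C@H]3C)n(C)c2n1`: 27 nM
Compound 3, `C[C@@H]1CCCN1c1c(C#N)c2c(N)nc(N)nc2n1C`: 217 nM

These three compounds were tested in an assay on isolated protein for inhibition of Leucine-rich repeat serine/threonine-protein kinase 2 variant G2019S (Homo sapiens), read by TR-FRET and LanthaScreen, with stated times of 50 min and 30 min, in the presence of a further agent that is not named here; a lower number here means a stronger inhibitor, a higher number a weaker inhibitor. Compound 3 stands in the middle of the three: compound 2 gives the lowest number, and compound 1 the highest. Among the compounds with values here, the one step that can be traced directly, an 8.0-fold higher number from compound 2 to compound 3 (0.91 log units; beyond the scatter), concerns a different position from the one now in question.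

The next compound, compound 4, has the structure `C[C@@H]1CCCN1c1c(C#N)c2c(N)ncnc2n1C`. It differs from compound 3 in one place: hydrogen in place of amino on an aromatic carbon. Within the data shown here, no measured pair shows exactly this change. Compound 1 also carries a hydrogen at that place, but it lacks the nitrile of compound 4 as well, so its value cannot be read as the effect of the amino alone; the two values of compound 1 and compound 3 only show that the pair with two differences lies far apart. The nearest clue is that making the group at this place smaller, as in the step from compound 2 to compound 3, raised the number; taking the group away entirely is expected to raise it again, likely by a larger margin than the scatter.

On that basis compound 4 is expected to give about 1500 nM in this assay, with a plausible range of 400 nM to 6000 nM, a step of a 6.9-fold higher number from compound 3 to compound 4 (0.84 log units; beyond the scatter) from compound 3.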

Compound 4, half-maximal inhibitory concentration: 11 nM
The estimate for compound 4 lay 140-fold (2.13 log units) above the measured number; the whole stated range lies above it.
By their numbers in this assay, from the lowest: compound 4; then compound 2; then compound 3; then compound 1.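

In this assay, the aromatic carbon between two ring nitrogen atoms turns out to do better with no group at all: replacing amino with hydrogen gives a large gain (a 20-fold lower number from compound 3 to compound 4 (1.30 log units; beyond the scatter)), so the amino group of compound 3 is no asset at this place. The larger (3-methyl-1H-pyrazol-4-yl)amino group does not restore that loss either, since the same place carrying hydrogen still gives a modest gain (a 2.5-fold lower number from compound 2 to compound 4 (0.39 log units; beyond the scatter)), which makes compound 4 the strongest inhibitor of the four, with compound 2 second and compound 3 third. Within the data shown here, the nitrile can now also be read on its own for the first time, and its step is the largest seen here (a 580-fold lower number from compound 1 to compound 4 (2.76 log units; beyond the scatter)), which shows that the low number of compound 4 depends heavily on this cyano group.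

On these data alone, whether a small group such as methyl or fluorine at the place between the ring nitrogen atoms would keep or lose this strength remains open, as does whether chlorine could stand in for the nitrile. Nothing measured here explains why any of these steps runs the way it does.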